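From compound 2 to compound 4: a small expected step

The source may report more compounds than this note shows. Statements on the series, on what has been measured and on what is new or still open speak of the compounds shown alone.

Compound 1 `C#CCSc1nc(N/N=C/c2ccc(N(C)C)cc2)c2nnn(Cc3ccccc3)c2n1` gives 7620 nM
Compound 2 `CCCSc1nc(N/N=C/c2ccccc2Cl)c2nnn(Cc3ccccc3)c2n1` gives 10900 nM
Compound 3 `CCCSc1nc(N/N=C(\C)c2ccccc2O)c2nnn(Cc3ccccc3Cl)c2n1` gives 35000 nM

All three numbers come from a functional assay on MGC-803 cells (Homo sapiens) for antiproliferative activity, read by MTT assay, with a stated time of 72 h; on this read-out higher numbers stand for weaker inhibition and lower numbers for stronger inhibition (no two of these compounds differ in one place only). Compound 2 lies within the scatter of compound 1, while compound 3 gives a number beyond the scatter above compound 2.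

Compound 4 `CCCSc1nc(N/N=C/c2ccc(Br)cc2)c2nnn(Cc3ccccc3)c2n1` awaits measurement. It carries 4-bromophenyl in place of 2-chlorophenyl on a carbon with a double bond to nitrogen and otherwise matches compound 2. Going by the values given here, no measured pair tests this swap, so no step beyond the scatter is expected, only an estimated 1.2-fold lower number from compound 2 to compound 4 (0.08 log units; within the scatter) with no firm direction. In this assay the estimate for compound 4 is 9000 nM (expected range 3500 nM to 23000 nM).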

Compound 4, half-maximal inhibitory concentration: 34900 nM
The estimate for compound 4 lay 3.9-fold (0.59 log units) below the measured number, outside the stated range (above it).
By their numbers in this assay, from the lowest: compounds 1 and 2 (each within the scatter of the next); then compounds 4 and 3 (each within the scatter of the next).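

In this assay, going by these compounds alone, the change to 4-bromophenyl in place of 2-chlorophenyl on a carbon with a double bond to nitrogen gives a 3.2-fold higher number from compound 2 to compound 4 (0.51 log units; beyond the scatter), the only step here that alters one place alone. Within the data shown here, it shows that this position is not indifferent to which halogen-bearing phenyl it carries, something the earlier compounds, which differ in several places, could not show. Nothing measured here accounts for the step.

The swap alters both the halogen and its place on the ring, so the two effects remain unseparated. As far as these compounds go, whether 4-chlorophenyl or 2-bromophenyl would match compound 2 or compound 4 remains open.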